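The compounds below may be only part of what the source reports. "The series", "measured", "known", "first", "only" and "open" are said of these compounds alone.

Measured in an ADME assay on microsomes (Homo sapiens) for metabolic stability; a higher number here means that the compound lasts longer, a lower number that the compound disappears faster:
- Compound 1 `Cc1c(Oc2c(F)cccc2F)c(OC(C)C)nn1-c1ccc(C2CC2)cn1`: 0.1 h
- Compound 2 `Cc1c(Oc2c(F)cccc2F)c(OC(C)C)nn1-c1ncc(C2CC2)cc1F`: 0.45 h
- Compound 3 `Cc1c(Oc2c(F)cccc2F)c(OC(C)C)nn1-c1ncc(Br)cc1F`: 1 h

Compound 2 is the second highest of these three numbers, below compound 3 and above compound 1. Compound 4 `Cc1c(Oc2c(F)cccc2F)c(OC(C)C)nn1-c1ncc(C2CC2)cc1O` differs from compound 2 in one place: hydroxy in place of fluoro on an aromatic carbon. This puts hydroxy in place of fluoro on an aromatic carbon, ortho to a large group.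

The most relevant measurement concerns that same carbon, where fluoro in place of hydrogen gave a 4.5-fold higher number from compound 1 to compound 2 (0.65 log units; beyond the scatter). Removing the fluoro could therefore give back part of that gain. However, hydroxy is not hydrogen, and no measured compound carries it. The other two steps say less: a 2.2-fold higher number from compound 2 to compound 3 (0.35 log units; beyond the scatter) comes from bromo in place of cyclopropyl, a change elsewhere, and a 10-fold higher number from compound 1 to compound 3 (1.00 log units; beyond the scatter) combines both changes.

A small drop is therefore expected, with real uncertainty in either direction. The estimated step is a 1.5-fold lower number from compound 2 to compound 4 (0.18 log units; within the scatter). For compound 4 the expected half-life is 0.3 h, with an estimated range of 0.1 h to 0.9 h.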

Compound 4, half-life: 0.633 h
For compound 4 the middle estimate is 2.1-fold (0.32 log units) below the measured one; the measured number falls inside the stated range.
By their numbers in this assay, from the lowest: compound 1; then compounds 2, 4 and 3 (each within the scatter of the next, the first and the last beyond it).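

In this assay, hydroxy in place of fluoro on this aromatic carbon gives a 1.4-fold higher number from compound 2 to compound 4 (0.15 log units; within the scatter), so the two groups cannot be told apart at this position. Hydroxy in place of hydrogen on the same carbon gives a 6.3-fold higher number from compound 1 to compound 4 (0.80 log units; beyond the scatter), which shows that the gain over hydrogen is not confined to fluoro: it also appears with a group that brings a hydrogen-bond donor, which fluoro does not. No data here explain why either group outperforms hydrogen at this carbon.

The compounds shown leave open whether the gain extends to other groups on this carbon, such as methoxy, chloro or an amine. They also leave open how hydroxy behaves when bromo stands in place of the cyclopropyl group.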